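Moving the methoxy group on the benzyl arm of a bombesin agonist

The source may hold more compounds than are shown below. What is called first, only, known or untested is meant among the compounds shown, and "the series" means these compounds.

Measured compounds:
compound 1, `O=C(O)c1ccccc1-c1ccc(CCc2ncc(Cc3ccccc3F)[nH]2)cc1`, 9.5 nM
compound 2, `Cc1cccc(Cc2cnc(CCc3ccc(-c4ccccc4C(=O)O)cc3)[nH]2)c1`, 75 nM
compound 3, `COc1ccccc1Cc1cnc(CCc2ccc(-c3ccccc3C(=O)O)cc2)[nH]1`, 163 nM

In an in vitro functional assay on cells for agonist activity at Bombesin receptor subtype-3 (Mus musculus), read by luminescence and calcium flux (a higher number here means that more compound is needed for the effect, a lower number that less compound is needed), compound 1 gives 9.5 nM. Compound 2 gives 75 nM, and compound 3 gives 163 nM, the highest of the three numbers. The step of a 17-fold higher number from compound 1 to compound 3 (1.23 log units; beyond the scatter) and the step of a 2.2-fold higher number from compound 2 to compound 3 (0.34 log units; beyond the scatter) both place compound 3 beyond the scatter of its neighbours, and the step of a 7.9-fold higher number from compound 1 to compound 2 (0.90 log units; beyond the scatter) shows that compound 2 also sits well above compound 1.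

Compound 4, `COc1ccc(Cc2cnc(CCc3ccc(-c4ccccc4C(=O)O)cc3)[nH]2)cc1`, has not yet been measured in this assay. It differs from compound 3 as follows: 4-methoxyphenyl in place of 2-methoxyphenyl on a saturated chain carbon bound to an aromatic carbon. The same atoms are present in both, joined differently. Going by the values given here, none of the three measured steps moves a methoxy group from one position of the phenyl ring to another, so no step bears directly on this change. The steps that do involve this phenyl ring all change the substituent itself, and the two involving compound 3 are both increases. There is therefore no measured basis for expecting a shift in either direction beyond the scatter, and the estimate for compound 4 is kept close to compound 3 with a broad range: 150 nM, between 40 nM and 600 nM, a step of a 1.1-fold lower number from compound 3 to compound 4 (0.04 log units; within the scatter) that is expected rather than known.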

Compound 4, half-maximal effective concentration: 513 nM
Estimate against measurement, compound 4: 3.4-fold (0.53 log units) below, within the range that was stated.
By their numbers in this assay, from the lowest: compound 1; then compound 2; then compound 3; then compound 4.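

The result shows that where the methoxy group sits on this ring matters, and not only which substituent is present. With the same atoms joined differently, going from 2-methoxybenzyl to 4-methoxybenzyl gives a 3.1-fold higher number from compound 3 to compound 4 (0.50 log units; beyond the scatter), so the position alone produces a change beyond the scatter. It also extends the range of the series upward, since the 4-methoxyphenyl group gives a 6.8-fold higher number from compound 2 to compound 4 (0.84 log units; beyond the scatter) and a 54-fold higher number from compound 1 to compound 4 (1.73 log units; beyond the scatter), the widest gap among the compounds shown, leaving the 2-fluorophenyl group of compound 1 with the lowest number and the two methoxy isomers with the highest. No measurement is available to explain why the position has this effect.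

Going by these compounds, only the methoxy group appears here in two positions, so it remains open whether moving the fluoro group of compound 1 or the methyl group of compound 2 around the ring would give a step of similar direction or size. Also open, on these data alone, is how a chloro, a hydroxyl or an amine on this ring would compare with the 2-fluorophenyl group of compound 1, and whether a longer chain at this place would change the order.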